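A Fluorine Added to an Inactive Triazole Pair

The compounds below may be only part of what the source reports. "The series", "measured", "known", "first", "only" and "open" are said of these compounds alone.

Compound 1 `Cc1c(O)ccc2c1[C@H](Cn1cc(-c3ccccc3)nn1)[C@@]13CC(=O)[C@@](C)(CC[C@@H]21)C3` and compound 2 `Cc1c(O)ccc2c1[C@H](Cn1cc(-c3ccc(F)cc3)nn1)[C@@]13CC(=O)[C@@](C)(CC[C@@H]21)C3` share one core and differ only in the change (fluoro in place of hydrogen on an aromatic carbon). Both were tested in a functional assay on A549 cells (Homo sapiens) for cytotoxicity, read by MTT assay, with a stated time of 4 days; on this read-out higher numbers stand for weaker inhibition and lower numbers for stronger inhibition. In this assay compound 1 gives > 20000 nM, which is a limit of the assay rather than a number. Compound 2 likewise gives > 20000 nM, again a limit. The resulting step that the two limits leave unreadable from compound 1 to compound 2 therefore cannot be sized from these two values.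

Compound 3 `C=C1C[C@]23C[C@@]1(O)CC[C@H]2c1cc(Br)c(O)c(C)c1[C@@H]3Cn1cc(-c2ccccc2)nn1` carries a different core; how its core differs from that of compound 1 is not broken down here. In this assay compound 3 gives > 20000 nM, once more a limit. Among the compounds with values here, the not yet measured compound 4 `C=C1C[C@]23C[C@@]1(O)CC[C@H]2c1cc(Br)c(O)c(C)c1[C@@H]3Cn1cc(-c2ccc(F)cc2)nn1` is reached from compound 3 by the change (fluoro in place of hydrogen on an aromatic carbon), the same change as the one from compound 1 to compound 2, made at a place described in the same words.

All that is known so far is the limit of > 20000 nM in this assay, at which 3 of the 3 values shown sit. Since the fluoro group did not move compound 2 off that limit relative to compound 1, compound 4 is expected to remain where compound 3 sits, with an expected step that the limit leaves unreadable from compound 3 to compound 4. The estimate for compound 4 is therefore 30000 nM, with an expected range from 15000 nM to 80000 nM, most probably reported only as a limit.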

Compound 4, half-maximal inhibitory concentration: 17900 nM
Compound 4: the middle estimate sits 1.7-fold (0.22 log units) above what was measured, and the stated range covers the measured number.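

In this assay, replacing phenyl with 4-fluorophenyl on the core of compound 3 gives an at least 1.1-fold lower number from compound 3 to compound 4 (0.04 log units; that floor lies within the scatter), so this core yields one measured number, yet even the smallest step it allows cannot be told apart from repeat-to-repeat variation. The same change on the core of compound 1 gives a step that cannot be read, as the values of compound 1 and compound 2 are both limits, so the two cores cannot be compared and nothing here shows that the effect of the change carries over from one to the other, or that it fails to. Most of this comparison therefore rests on limits rather than on numbers: the limit of > 20000 nM in this assay, at which 3 of the 4 values shown sit.

On these data alone, the true size of the step from compound 3 to compound 4 stays open, as does whether the fluoro group has any effect at all on the core of compound 1. Also open, as far as these compounds go, is what a different group in the same place on the aromatic ring, such as an amine or a carboxylic acid, would do on either core, and whether it would give a clearly lower number in this assay.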